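A Larger Ester Group on the Weakest Compound

The source may hold more compounds than are shown below. What is called first, only, known or untested is meant among the compounds shown, and "the series" means these compounds.

In a functional assay on A549 cells (Homo sapiens) for antiproliferative activity, read by MTT assay, with a stated time of 48 h (a lower number here means a stronger inhibitor, a higher number a weaker inhibitor), compound 1 `CC(=O)OC/C1=C/C[C@](C)(CCC=C(C)C)/C=C/[C@@H](OC(=O)C=C(C)C)[C@](C)(O)/C=C/C1=O` gives 2950 nM and compound 2 `CC(C)=CCC[C@]1(C)/C=C/[C@@H](OC(=O)C=C(C)C)[C@](C)(O)/C=C/C(=O)/C(CN(C)C)=C\C1` gives 590 nM. Compound 3 `CC(=O)O[C@@H]1/C=C/[C@@](C)(CCC=C(C)C)C/C=C(/CO)C(=O)/C=C/[C@@]1(C)O` has the highest number of the three at 8670 nM, which makes it the weakest inhibitor so far. Compound 4 `CC(C)=CCC[C@]1(C)/C=C/[C@@H](OC(=O)C(C)C)[C@](C)(O)/C=C/C(=O)/C(CO)=C\C1` differs from it by one change: isopropyl in place of methyl on a carbonyl carbon. Among the compounds with values here, no measured step tests this change directly. Within the data shown here, the only step available, a 5.0-fold lower number from compound 1 to compound 2 (0.70 log units; beyond the scatter), was modest and involved a different group, so it offers only a rough guide to size. A similarly modest lowering is therefore expected, though with little confidence in its direction. The estimated step is a 2.2-fold lower number from compound 3 to compound 4 (0.34 log units; beyond the scatter). Compound 4 is estimated at 4000 nM, with an expected range of 1800 nM to 9000 nM.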

Compound 4, half-maximal inhibitory concentration: 10800 nM
Estimate against measurement, compound 4: 2.7-fold (0.43 log units) below; measured number above the stated range.
By their numbers in this assay, from the lowest: compound 2; then compound 1; then compounds 3 and 4 (each within the scatter of the next).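

In this assay, swapping methyl for isopropyl on a carbonyl carbon, which turns acetoxy into (isopropylcarbonyl)oxy, gives a 1.2-fold higher number from compound 3 to compound 4 (0.10 log units; within the scatter) and so leaves the two compounds indistinguishable. At this position, then, two extra carbons on the ester produce no readable change in antiproliferative activity. Nothing measured here offers a reason for this result.

As far as these compounds go, whether a much longer chain or a phenyl group on this carbonyl carbon would shift the number beyond the scatter stays open.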